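The source may report more compounds than this note shows. Statements on the series, on what has been measured and on what is new or still open speak of the compounds shown alone.

Compound 1 `COc1cccc(/C=N/Nc2ncc3c(n2)n(C2CCCC2)c(=O)c(=O)n3C)c1` is the starting point. In a functional assay on PC-3 cells (Homo sapiens) for antiproliferative activity, read by MTT assay (a higher number here means a weaker inhibitor, a lower number a stronger inhibitor), compound 1 gives 20700 nM, the highest of the two plain numbers shown, though its nearest neighbour sits within the scatter. Compound 2 `Cn1c(=O)c(=O)n(C2CCCC2)c2nc(N/N=C/c3cccc(Cl)c3Cl)ncc21` gives 17200 nM in this assay, and the step of a 1.2-fold lower number from compound 1 to compound 2 (0.08 log units; within the scatter) is too small to call a change. Compound 3 `COc1ccc(/C=N/Nc2ncc3c(n2)n(C2CCCC2)c(=O)c(=O)n3C)c(OC)c1` reaches only a limit of this assay, > 100000 nM, so no number is known for it. The steps of an at least 4.8-fold higher number from compound 1 to compound 3 (0.68 log units; beyond the scatter) and an at least 5.8-fold higher number from compound 2 to compound 3 (0.76 log units; beyond the scatter) show that swapping the substituted phenyl can weaken inhibition beyond the scatter.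

Compound 4 `Cn1c(=O)c(=O)n(C2CCCC2)c2nc(N/N=C/c3cccc(O)c3)ncc21` differs from compound 1 by hydrogen in place of methyl on an oxygen on an aromatic ring, that is, methoxy to hydroxy. No measured step trades a methoxy for a hydroxy, so the shown steps bear on this change only loosely: small aryl swaps gave no change, larger ones weakened. The expectation is therefore a step of a 1.1-fold higher number from compound 1 to compound 4 (0.03 log units; within the scatter) that stays within the scatter. Compound 4 is estimated at 22000 nM, between 7000 nM and 70000 nM.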

Compound 4, half-maximal inhibitory concentration: 36300 nM
Compound 4: middle estimate off by 1.7-fold (0.22 log units), on the low side, and the stated range covers the measured number.
By their numbers in this assay, from the lowest: compounds 2, 1 and 4 (each within the scatter of the next, the first and the last beyond it). At a limit, above all of these: compound 3.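

Among the compounds shown here, removing the methyl from this oxygen is the first change tested directly at this group, and the result is a 1.8-fold higher number from compound 1 to compound 4 (0.24 log units; within the scatter): the 3-hydroxyphenyl and 3-methoxyphenyl compounds cannot be told apart in this assay. The comparison with the dichlorinated compound gives a 2.1-fold higher number from compound 2 to compound 4 (0.32 log units; beyond the scatter), a modest weakening, even though the step from methoxy to hydroxy alone stays within the scatter. The step of an at least 2.7-fold lower number from compound 3 to compound 4 (0.44 log units; beyond the scatter) rests on a limit and not on a number: the limit of > 100000 nM in this assay, at which 1 of the 4 values shown sits.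

The compounds shown do not reveal how an amine or a carboxylic acid in place of the hydroxy would behave at this place. A longer chain on the oxygen, such as propyl in place of methyl, also remains an open question.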